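Methyl for isopropyl on the chain carbon of compound 2

The source may report more compounds than this note shows. Statements on the series, on what has been measured and on what is new or still open speak of the compounds shown alone.

Of the compounds shown here, three have been measured in a physicochemical assay for metabolic stability, read by HPLC, in phosphate buffer, at pH 7.7; a lower number here means that the compound disappears faster, a higher number that the compound lasts longer. Compound 1 `CCC(=O)N[C@@H](C)C(=O)N(C)/N=N/c1ccc(C#N)cc1` gives 10.1 h. Compound 2 `CC(=O)N[C@H](C(=O)N(C)/N=N/c1ccc(C#N)cc1)C(C)C` gives 84.3 h, the highest of the three numbers. Compound 3 `CC(=O)N[C@@H](C)C(=O)N(C)/N=N/c1ccc(C(C)=O)cc1` gives 13.9 h. Compound 2 stands beyond the scatter above both: compound 3 is the nearest, compound 1 the furthest.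

The step under consideration leads from compound 2 to compound 4 `CC(=O)N[C@@H](C)C(=O)N(C)/N=N/c1ccc(C#N)cc1`, which has not yet been measured in this assay. The change is methyl in place of isopropyl on a saturated chain carbon bound to an amide-type nitrogen and a carbonyl carbon. Compound 4 carries the same acetyl amide as compound 2 and compound 3 and the same nitrile-bearing aryl as compound 1 and compound 2. Compound 1 and compound 3 both carry a methyl on a saturated chain carbon bound to an amide-type nitrogen and a carbonyl carbon, and both sit well below compound 2.

Going by the values given here, no step between measured compounds is available, so the expectation rests on the spread of the three values. Because compound 2 stands at 84.3 h while the two methyl-bearing compounds sit far lower, a step of a 7.0-fold lower number from compound 2 to compound 4 (0.85 log units; beyond the scatter) is expected, downward, beyond the scatter. Compound 4 is expected to give about 12 h, within a range from 6 h to 25 h.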

Compound 4, half-life: 9.8 h
For compound 4 the middle estimate is 1.2-fold (0.09 log units) above the measured one; the measured number falls inside the stated range.
By their numbers in this assay, from the lowest: compounds 4, 1 and 3 (each within the scatter of the next); then compound 2.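

In this assay the change of isopropyl to methyl on a saturated chain carbon bound to an amide-type nitrogen and a carbonyl carbon now has a direct reading, with an 8.6-fold lower number from compound 2 to compound 4 (0.93 log units; beyond the scatter) as the only difference between the two structures, so the gap seen earlier no longer depends on comparing compounds that differ in more than one place. The other two changes stay within the scatter, with cyano in place of acetyl on an aromatic carbon giving a 1.4-fold lower number from compound 3 to compound 4 (0.15 log units; within the scatter) and hydrogen in place of methyl on a saturated chain carbon bound to a carbonyl carbon giving a 1.0-fold lower number from compound 1 to compound 4 (0.01 log units; within the scatter), which leaves the isopropyl-to-methyl change as the only one of the three with a step beyond the scatter. Nothing at hand bears on the cause of this step.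

On these data alone, whether an ethyl, a tert-butyl or a phenyl on this chain carbon would stand with compound 2 or with compound 4 remains open. Also open, as far as these compounds go, is whether isopropyl has the same effect alongside the acetyl-bearing aryl of compound 3 or the longer acyl chain of compound 1.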